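Shifting a Methyl Around the Alkyne-Linked Ring

The source may report more compounds than this note shows. Statements on the series, on what has been measured and on what is new or still open speak of the compounds shown alone.

Of the compounds shown here, two have been measured in an ADME assay on HEK293 cells for agonist activity at metabotropic glutamate receptor 5 (Rattus norvegicus), read by fluorescence and calcium flux; a higher number here means a larger maximal response, a lower number a smaller maximal response. Compound 1 `C[C@@H](NC(=O)c1ccc(C#Cc2ccc(F)cc2)cn1)C(C)(C)O` gives 38.4% in this assay, and compound 2 `Cc1ccccc1C#Cc1ccc(C(=O)N[C@H](C)C(C)(C)O)nc1` gives 24.1%. Among the measured compounds shown here, compound 2 thus stands at the lower of the two numbers; the one measured step, a number 14.3 percentage points lower from compound 1 to compound 2 (beyond the scatter), lies beyond the scatter. Compound 3 `Cc1cccc(C#Cc2ccc(C(=O)N[C@H](C)C(C)(C)O)nc2)c1` has not yet been measured. It differs from compound 2 only in the change (3-methylphenyl in place of 2-methylphenyl on a triple-bonded carbon). For the measured compounds named here, the single measured step bears on this only loosely: it swapped 4-fluorophenyl for 2-methylphenyl, whereas here 3-methylphenyl replaces 2-methylphenyl, the same atoms joined differently. Going by the values given here, with no step of that kind to go by, a small change is expected, if any beyond the scatter, with a slight lean upward given that compound 2 gives 24.1%. The expected step is a number 5.9 percentage points higher from compound 2 to compound 3 (within the scatter). For compound 3 the estimate in this assay is 30%, in a range from 12% to 50%.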

Compound 3, largest response reached (reported as efficacy), in percent of the reference or control that the assay uses: 20.8%
The estimate for compound 3 lay 9.2 percentage points above the measured number, within the range that was stated.
By their numbers in this assay, from the lowest: compounds 3 and 2 (each within the scatter of the next); then compound 1.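

Compound 2 and compound 3, which carry 2-methylphenyl and 3-methylphenyl on the triple-bonded carbon, cannot be told apart in this assay (a number 3.3 percentage points lower from compound 2 to compound 3 (within the scatter)), so the two placings of the methyl give no separable result here. The 3-methylphenyl group also falls short of the 4-fluorophenyl group of compound 1 (a number 17.6 percentage points lower from compound 1 to compound 3 (beyond the scatter)), in the same direction as the earlier step to 2-methylphenyl, so both methylphenyl compounds stand apart from compound 1. No measurement at hand offers a reason for this pattern.

From the compounds shown here alone, it remains open whether a 4-methylphenyl group would sit with the two methylphenyl compounds or with compound 1. Also open, going by these compounds, is what a plain phenyl ring, or a chloro or methoxy group on that ring, would give.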